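Shortening the ring on the amine nitrogen

The source may report more compounds than this note shows. Statements on the series, on what has been measured and on what is new or still open speak of the compounds shown alone.

Within the data shown here, compound 3 `CCCn1c(-c2ccccc2)nc2c(NC3CCCCC3)ncnc21` gives 27 nM in an assay on CHO cells for displacement of a labelled ligand from adenosine receptor A1 (Homo sapiens), read by scintillation counting, with a stated time of 3 h (on this read-out lower numbers stand for stronger inhibition and higher numbers for weaker inhibition), the highest of the three numbers measured so far. Its nearest neighbour is compound 2 `CCCn1c(-c2ccccc2)nc2c(NC3CCOC3)ncnc21`, which gives 25 nM; its furthest is compound 1 `Cn1c(-c2ccccc2)nc2c(NC3CCCC3)ncnc21`, which gives 2.8 nM. Among the measured compounds shown here, the one measured step that touches the same place, a 1.1-fold higher number from compound 2 to compound 3 (0.03 log units; within the scatter), stays within the scatter.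

Compound 4 `CCCn1c(-c2ccccc2)nc2c(NC3CCCC3)ncnc21` has not been measured. It differs from compound 3 in one place: cyclopentyl in place of cyclohexyl on a nitrogen on an aromatic ring. For the measured compounds named here, no measured step follows this exact change, and compound 1, the only compound that carries a cyclopentyl group, differs from compound 4 elsewhere as well, so the two values of compound 1 and compound 3 are the only guide. They sit far apart, but how much of that gap belongs to the ring on the nitrogen cannot be read from the data.

Compound 4 is therefore expected to give 12 nM, within a range of 4 nM to 40 nM, meaning an estimated step of a 2.3-fold lower number from compound 3 to compound 4 (0.35 log units; beyond the scatter) that could well turn out to lie within the scatter.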

Compound 4, inhibition constant: 10 nM
Compound 4: the middle estimate sits 1.2-fold (0.08 log units) above what was measured, and the stated range covers the measured number.
By their numbers in this assay, from the lowest: compound 1; then compound 4; then compounds 2 and 3 (each within the scatter of the next).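

In this assay, the group on this nitrogen now shows an effect: cyclopentyl gives a lower number than cyclohexyl (a 2.7-fold lower number from compound 3 to compound 4 (0.43 log units; beyond the scatter)) and than oxolan-3-yl (a 2.5-fold lower number from compound 2 to compound 4 (0.40 log units; beyond the scatter)), both beyond the scatter, whereas the earlier exchange of oxolan-3-yl for cyclohexyl (a 1.1-fold higher number from compound 2 to compound 3 (0.03 log units; within the scatter)) had separated nothing. Among these compounds, with cyclopentyl held constant, the chain on the aromatic nitrogen can also be read on its own for the first time, and its lengthening raises the number by a modest step (a 3.6-fold higher number from compound 1 to compound 4 (0.55 log units; beyond the scatter)), so the shared core responds to a change at either place. Nothing measured here accounts for either step, and no supporting data on the reason for them are available.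

Going by these compounds, it remains open whether the trend continues with a smaller ring such as cyclobutyl or cyclopropyl, or whether an open chain such as isopropyl on the same nitrogen would match cyclopentyl. Equally unsettled is whether a longer chain such as butyl on the aromatic nitrogen would raise the number further, and whether the chain step would keep its size with cyclohexyl in place of cyclopentyl.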